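Acyl aryl change in compound 2 and expected tolerance

The compounds below may be only part of what the source reports. "The series", "measured", "known", "first", "only" and "open" are said of these compounds alone.

Compound 1 `Cc1cccc(C(=O)N(C(=S)OCCN2C(=O)c3ccccc3C2=O)c2ccc(Cl)cc2)c1` gives 58000 nM in an ADME assay on MT4 cells (Homo sapiens) for cytotoxicity, read by MTT assay; a higher number here means that more compound is tolerated, a lower number that less compound is tolerated. Compound 3 `O=C1c2ccccc2C(=O)N1CCOC(=S)N(C(=O)c1cc(F)ccc1F)c1ccc(Cl)cc1` gives 54000 nM in this assay, and the change between them, a swap of the aryl on the carbonyl carbon, is a 1.1-fold lower number from compound 1 to compound 3 (0.03 log units; within the scatter). Compound 2 `Cc1ccc(N(C(=O)c2cccc(C)c2)C(=S)OCCN2C(=O)c3ccccc3C2=O)cc1` reaches only a limit of the assay in this assay, > 100000 nM. The step of an at least 1.7-fold higher number from compound 1 to compound 2 (0.23 log units; that floor lies within the scatter) accordingly ends at the limit of > 100000 nM in this assay, at which 1 of the 3 values shown sits, so compound 2 stands at the top of the numbers shown rather than at a measured value. Compound 4 `Cc1ccc(N(C(=O)c2cccc(Cl)c2Cl)C(=S)OCCN2C(=O)c3ccccc3C2=O)cc1` has not yet been measured; it differs from compound 2 by 2,3-dichlorophenyl in place of 3-methylphenyl on a carbonyl carbon. Going by the values given here, the only measured step that alters the aryl on the carbonyl carbon, a 1.1-fold lower number from compound 1 to compound 3 (0.03 log units; within the scatter), stayed within the scatter, so no shift beyond the scatter is expected here, and compound 2 already sits at the limit. The step is therefore expected to be a number no higher from compound 2 to compound 4 (the limit leaves the size open). Compound 4 is estimated at 100000 nM, with a range from 50000 nM to 200000 nM, most likely again reported as a limit.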

Compound 4, half-maximal cytotoxic concentration: 35000 nM
Estimate against measurement, compound 4: 2.9-fold (0.46 log units) above; measured number below the stated range.
By their numbers in this assay, from the lowest: compounds 4, 3 and 1 (each within the scatter of the next). At a limit, above all of these: compound 2.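

In this assay, a change of the aryl on the carbonyl carbon now moves the number beyond the scatter: an at least 2.8-fold lower number from compound 2 to compound 4 (0.45 log units; beyond the scatter). The earlier change at this place, a 1.1-fold lower number from compound 1 to compound 3 (0.03 log units; within the scatter), stayed within the scatter, so this place does not tolerate every aryl alike, although the two changes were made on different partners and 2,3-dichlorophenyl was tried only on the one. Going by these compounds, the step is only a floor, and its full size stays open, because compound 2 sits at a limit: the limit of > 100000 nM in this assay, at which 1 of the 4 values shown sits.

The compounds shown leave open whether the lower number follows the chlorine atoms as such or the 2,3-dichlorophenyl group as a whole, and whether the same change holds on the core of compound 1. They also leave open how an aryl carrying an amine or a carboxylic acid would behave at this place.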